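The source may hold more compounds than are shown below. What is called first, only, known or untested is meant among the compounds shown, and "the series" means these compounds.

Measured in a functional assay on HCT-116 cells (Homo sapiens) for inhibition, read by sulforhodamine B assay, with a stated time of 48 h, tested at 50 uM; on this read-out higher numbers stand for more inhibition of growth at the one concentration tested and lower numbers for less inhibition of growth:
- Compound 1 `COc1cc(/C=C/C(=O)/C=C/c2cccc3ccccc23)ccc1OCc1cn(CCOc2cc(=O)oc3ccccc23)nn1`: 83%
- Compound 2 `COc1ccccc1/C=C/C(=O)/C=C/c1ccc(OCc2cn(CCCOc3cc(=O)oc4ccccc34)nn2)c(OC)c1`: 53%
- Compound 3 `COc1cc(/C=C/C(=O)/C=C/c2cc(OC)c(OC)c(OC)c2)ccc1OCc1cn(CCOc2cc(=O)oc3ccccc23)nn1`: 89%

Of these three, compound 2 stands lowest at 53%, with compound 1 and compound 3 both beyond the scatter from it. The next compound to consider is compound 4 `COc1cc(/C=C/C(=O)/C=C/c2cc(OC)c(OC)c(OC)c2)ccc1OCc1cn(CCCOc2cc(=O)oc3ccccc23)nn1`, which departs from compound 2 by one change: 3,4,5-trimethoxyphenyl in place of 2-methoxyphenyl on a double-bonded chain carbon bound to a double-bonded chain carbon. This places 3,4,5-trimethoxyphenyl in place of 2-methoxyphenyl on a double-bonded chain carbon bound to a double-bonded chain carbon.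

For the measured compounds named here, only one measured step touches that place: a number 6 percentage points higher from compound 1 to compound 3 (within the scatter). It is small, but it starts from naphthalen-1-yl rather than 2-methoxyphenyl, and it sits in a different chain setting, so it transfers only loosely. Compound 3 carries the entering group and reads 89%, yet compound 3 also differs from compound 4 in the chain. The data do not show how much of the gap between compound 2 and compound 3 belongs to the aryl group and how much to the chain. A moderate rise is therefore expected, one that recovers part of that gap, though a step within the scatter cannot be ruled out.

The expected change is a number 15 percentage points higher from compound 2 to compound 4 (beyond the scatter). For compound 4 the estimate is 68%, with an expected range of 50% to 88%.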

Compound 4, percent growth inhibition at one concentration: 76%
Estimate against measurement, compound 4: 8 percentage points below; measured number inside the range.
By their numbers in this assay, from the lowest: compound 2; then compounds 4, 1 and 3 (each within the scatter of the next, the first and the last beyond it).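

In this assay, putting 3,4,5-trimethoxyphenyl in place of 2-methoxyphenyl gives a number 23 percentage points higher from compound 2 to compound 4 (beyond the scatter) and so shows that the group on a double-bonded chain carbon bound to a double-bonded chain carbon can move this read-out beyond the scatter. The same entering group gave only a number 6 percentage points higher from compound 1 to compound 3 (within the scatter) when it replaced naphthalen-1-yl, so the size of the step at this place differs with the group that leaves, and the low reading of compound 2 is now tied at least in part to its 2-methoxyphenyl. No measured evidence explains the rise or says what the added methoxy groups contribute.

On these data alone, with the same 3,4,5-trimethoxyphenyl group, compound 3 reads 89% and compound 4 reads 76%, but this one pair cannot show whether the chain has a general effect, and a longer chain remains open. Also open, as far as these compounds go, is how an amine or a carboxylic acid on the aryl ring at this place would read, and whether any of these readings at a single concentration would hold across a full range of concentrations.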